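This account rests on a few compounds, and the source may have more. Where it says the series, first, only, none or still open, it means among the compounds named here.

Compound 1, `Cc1ccc(-c2cc(NC(=O)c3ccc(Cl)nc3)n[nH]2)cc1`, gives 5720 nM in a functional assay on WM 266-4 cells (Homo sapiens) for antiproliferative activity, read by MTT assay, with a stated time of 48 h; on this read-out lower numbers stand for stronger inhibition and higher numbers for weaker inhibition. Compound 2, `COc1ccc(C(=O)Nc2cc(-c3ccc(C)cc3)[nH]n2)cn1`, gives 7350 nM in this assay, and the change between them, (methoxy in place of chloro on an aromatic carbon), made a 1.3-fold higher number from compound 1 to compound 2 (0.11 log units; within the scatter). Compound 3, `O=C(Nc1cc(-c2ccc(Br)cc2)[nH]n1)c1cccnc1Cl`, gives 6990 nM; the difference between its core and that of compound 1 is not broken down here. Compound 4, `COc1ncccc1C(=O)Nc1cc(-c2ccc(Br)cc2)[nH]n1`, is not yet measured; it differs from compound 3 by methoxy in place of chloro on an aromatic carbon. Among the compounds with values here, this is the same kind of change as the one from compound 1 to compound 2, though the place is para to a large group in the earlier pair and ortho to a large group here. The step from compound 3 to compound 4 is expected to be a 1.3-fold higher number from compound 3 to compound 4 (0.11 log units; within the scatter), resting on a 1.3-fold higher number from compound 1 to compound 2 (0.11 log units; within the scatter). Compound 4 is therefore estimated at 9000 nM, expected to lie between 4500 nM and 18000 nM.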

Compound 4, half-maximal inhibitory concentration: 10300 nM
For compound 4 the middle estimate is 1.1-fold (0.06 log units) below the measured one, within the range that was stated.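

In this assay, methoxy in place of chloro made a 1.5-fold higher number from compound 3 to compound 4 (0.17 log units; within the scatter). Within what these two pairs can resolve, the change carried from one core to the other without a detectable difference: the same change on two cores in this assay, a 1.3-fold higher number (0.11 log units; within the scatter) from compound 1 to compound 2 and a 1.5-fold higher number (0.17 log units; within the scatter) from compound 3 to compound 4, 1.1-fold (0.06 log units) apart, within the scatter of two such steps. This shows that the two steps agree, but it does not show that the change has a real effect on the number in either pair, and two cores cannot establish that the agreement would hold across the wider series.

The compounds shown leave open whether an amine or a carboxylic acid in place of the chloro would shift the number beyond the scatter on either core.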